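This account rests on a few compounds, and the source may have more. Where it says the series, first, only, none or still open, it means among the compounds named here.

Three compounds of the series carry numbers in a functional assay on HepG2 cells (Homo sapiens) for inhibition, read by MTT assay, with a stated time of 72 h; on this read-out higher numbers stand for weaker inhibition and lower numbers for stronger inhibition. Compound 1 `O=C(Nc1ccc(Oc2ccnc3[nH]ccc23)cc1)c1cn(-c2ccc(Cl)cc2)c2ccccc2c1=O` gives 250 nM. Compound 2 `Cn1ccc2c(Oc3ccc(NC(=O)c4cn(-c5ccc(Cl)cc5)c5ccccc5c4=O)cc3F)ccnc21` gives 290 nM. Compound 3 `O=C(Nc1ccc(Oc2ccnc3[nH]ccc23)c(F)c1)c1cn(-c2ccc(Cl)cc2)c2ccccc2c1=O` gives 380 nM, the highest of the three numbers, though its gap to compound 2 and its gap to compound 1 both lie within the scatter, so no order among the three can be read. The two measured steps are a 1.5-fold higher number from compound 1 to compound 3 (0.18 log units; within the scatter) and a 1.3-fold higher number from compound 2 to compound 3 (0.12 log units; within the scatter); each lies within the scatter, and neither touches the 4-chlorophenyl group.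

Compound 4 `COc1ccc(-n2cc(C(=O)Nc3ccc(Oc4ccnc5[nH]ccc45)c(F)c3)c(=O)c3ccccc32)cc1` differs from compound 3 by methoxy in place of chloro on an aromatic carbon. Among the compounds with values here, no measured step bears on this change, as the 4-chlorophenyl group is kept in all three measured compounds. Within the data shown here, the only guidance is that single-point changes elsewhere have so far moved the numbers in this assay by no more than the scatter. On that basis the expected step is a 1.2-fold higher number from compound 3 to compound 4 (0.07 log units; within the scatter), not beyond the scatter. Compound 4 is therefore expected to give about 450 nM in this assay, within a range of 180 nM to 1200 nM.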

Compound 4, half-maximal inhibitory concentration: 6530 nM
For compound 4 the middle estimate is 15-fold (1.16 log units) below the measured one; measured number above the stated range.
By their numbers in this assay, from the lowest: compounds 1, 2 and 3 (each within the scatter of the next); then compound 4.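

In this assay, within the data shown here, the change from 4-chlorophenyl to 4-methoxyphenyl gives a 17-fold higher number from compound 3 to compound 4 (1.24 log units; beyond the scatter), the only step so far that lies beyond the scatter. Among these compounds, the earlier steps, fluoro in place of hydrogen and hydrogen in place of methyl on an aromatic nitrogen, showed no such sensitivity, so this position on the aromatic ring, para to a large group, is the first place where a single change clearly moves the number. No measurement at hand accounts for the size of this step.

From the compounds shown here alone, it remains open whether the step follows from the loss of chloro or the entry of methoxy, and fluoro, methyl or an amine at this place would help separate the two. Also open, going by these compounds, is whether the same change gives a comparable step on compound 1 or compound 2.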